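The source may hold more compounds than are shown below. What is called first, only, known or untested is meant among the compounds shown, and "the series" means these compounds.

Within the data shown here, compound 3 `COc1ccc(C2=NN(c3ccc(S(N)(=O)=O)cc3)C(c3cn(-c4ccccc4)nc3-c3ccc(Cl)cc3)C2)cc1` is the one compound among the three measured that gives an actual number in an ADME assay on Vero cells (Chlorocebus sabaeus) for cytotoxicity, read by MTT assay, with a stated time of 72 h; a higher number here means that more compound is tolerated, a lower number that less compound is tolerated: compound 3 gives 31300 nM. Compound 1 `NS(=O)(=O)c1ccc(N2N=C(c3ccc(O)cc3)CC2c2cn(-c3ccccc3)nc2-c2ccccc2)cc1` reaches only a limit of this assay, > 160000 nM. Compound 2 `NS(=O)(=O)c1ccc(N2N=C(c3ccc(Cl)cc3)CC2c2cn(-c3ccccc3)nc2-c2ccc(Cl)cc2)cc1` likewise reaches only a limit, > 164000 nM. Among the measured compounds shown here, the single measured step with a direction, an at least 5.2-fold lower number from compound 2 to compound 3 (0.71 log units; beyond the scatter), is at least modest. Compound 4 `COc1ccc(C2=NN(c3ccc(S(N)(=O)=O)cc3)C(c3cn(-c4ccccc4)nc3-c3ccc(C)cc3)C2)cc1` differs from compound 3 by methyl in place of chloro on an aromatic carbon. For the measured compounds named here, no measured step exchanges chloro for methyl, so there is no direct guide for this change. The step of a 1.1-fold higher number from compound 3 to compound 4 (0.05 log units; within the scatter) is therefore expected to stay within the usual scatter. Compound 4 is estimated at 35000 nM, with a range from 12000 nM to 100000 nM.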

Compound 4, half-maximal cytotoxic concentration: > 36600 nM
Compound 4 was reported as a limit; the forecaster's own chance of this, stated with the estimate: 20%; at least 1.0-fold (0.01 log units) between middle value and limit.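

Among these compounds, this is the first measured change at the 4-chlorophenyl group of compound 3; the earlier step altered a different place. In this assay the swap to 4-methylphenyl gives an at least 1.1-fold higher number from compound 3 to compound 4 (0.06 log units; that floor lies within the scatter) and so brings no lower number at this position. The real size of this step stays unknown because compound 4 gives only a limit: the limit of > 36600 nM in this assay, at which 1 of the 4 values shown sits.

Going by these compounds, whether an amine or a carboxylic acid at this position would lower the number remains open. So does whether methyl in place of chloro would read the same on a different core.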